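The compounds below may be only part of what the source reports. "The series", "measured", "known", "first", "only" and "open" are said of these compounds alone.

Measured compounds:
- compound 1, `COc1ccc(Cl)cc1Nc1nc2c(s1)CCCCc1nc(N)sc1-2`, 9200 nM
- compound 2, `COC(=O)CCC(=O)Nc1nc2c(s1)-c1nc(Nc3cc(Cl)ccc3OC)sc1CCCC2`, 8300 nM
- compound 3, `CN(C)c1ccc(Cl)cc1Nc1nc2c(s1)CCCCc1nc(NC(=O)C(C)(C)C)sc1-2`, 2100 nM

In an assay on cells (Epithelial cell) with Cystic fibrosis transmembrane conductance regulator variant F508del (Homo sapiens) as the target, read by fluorescence, with a stated time of 20 h (on this read-out lower numbers stand for stronger inhibition and higher numbers for weaker inhibition), compound 3 gives the lowest number of the three; compound 2 stands nearest to it with a higher number, and compound 1 stands furthest, also higher, both gaps beyond the scatter. Compound 4, `CN(C)c1cccc(Nc2nc3c(s2)CCCCc2nc(NC(=O)C(C)(C)C)sc2-3)c1`, has not yet been measured. It differs from compound 3 in one place: 3-(dimethylamino)phenyl in place of 5-chloro-2-(dimethylamino)phenyl on a nitrogen on an aromatic ring.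

Going by the values given here, only one measured step exists, a 1.1-fold lower number from compound 1 to compound 2 (0.04 log units; within the scatter), and it changes the amide on the other side of the shared core, not the aryl group on the nitrogen. Among the compounds with values here, no measured step touches the aryl group alone; compounds 1 and 2 carry a different aryl group and a different amide from compound 3, so their gap to compound 3 mixes two changes. Within the data shown here, the change to compound 4 therefore has no direct precedent, and the expectation rests on the loss of the chlorine and the shifted dimethylamino alone. Compound 4 is estimated to give 5000 nM in this assay, with a range from 1500 nM to 16000 nM, which would mean a step of a 2.4-fold higher number from compound 3 to compound 4 (0.38 log units; beyond the scatter), expected to be a modestly higher number than compound 3 but uncertain in both directions.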

Compound 4, half-maximal inhibitory concentration: 5200 nM
Beside the measured number, compound 4's estimate is 1.0-fold (0.02 log units) below it, and the stated range covers the measured number.
By their numbers in this assay, from the lowest: compound 3; then compounds 4, 2 and 1 (each within the scatter of the next).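

In this assay the aryl group on the nitrogen is now seen to count on its own: with the amide on the other side of the shared core held fixed, 3-(dimethylamino)phenyl in place of 5-chloro-2-(dimethylamino)phenyl gives a 2.5-fold higher number from compound 3 to compound 4 (0.39 log units; beyond the scatter), a modest step but one beyond the scatter. Going by these compounds alone, the only earlier step, a 1.1-fold lower number from compound 1 to compound 2 (0.04 log units; within the scatter), changed that amide rather than the aryl group and stayed within the scatter, so it said nothing about this position, and the gaps from compounds 1 and 2 to compound 3 mixed two changes. Nothing available on these compounds accounts for the rise in the number.

The compounds shown leave open how much of the step goes with the loss of the chlorine and how much with the changed place of the dimethylamino group, as the two changes arrive together in this one pair. They also leave open how a nitrile or a morpholine on that phenyl ring would read, and whether the step would keep its size with a different amide on the shared core.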